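Lengthening a side chain on a shared quinone-like core

The source may hold more compounds than are shown below. What is called first, only, known or untested is meant among the compounds shown, and "the series" means these compounds.

Measured so far:
compound 1, `CCCC1=C(N2CC2)C(=O)C(CCC)=C(N2CC2)C1=O`: 4.92
compound 2, `CCC1=C(N2CC2)C(=O)C(CCOC(N)=O)=C(N2CC2)C1=O`: 6.25

Both compounds were tested in a functional assay on L1210 cells (Mus musculus), with a stated time of 12 days; on this read-out lower numbers stand for lower potency and higher numbers for higher potency (the scale is a negative logarithm). Of the two numbers, compound 2 stands highest, and compound 1 sits a long way lower, beyond the scatter. Among the compounds with values here, no single-point step between them is available, as they differ in more than one place, so the numbers alone are all that can be said.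

Compound 3, `CCCC1=C(N2CC2)C(=O)C(CCOC(N)=O)=C(N2CC2)C1=O`, has not yet been measured in this assay. It differs from compound 2 in one place: methyl in place of hydrogen on a saturated chain carbon, two bonds along the chain from a double-bonded ring carbon. Read one bond further out, the same change is ethyl to propyl. Such a small change in a side chain gives no basis for a large shift, and a step of about the size of the scatter, with no clear direction, is expected: a number 0.15 log units lower from compound 2 to compound 3 (within the scatter). Compound 3 is therefore estimated at 6.1, within a range from 5.5 to 6.7.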

Compound 3, logarithm of the reciprocal of the active concentration, log(1/C): 5.68
The estimate for compound 3 lay 0.42 log units above the measured number; low and high end bracket the measured number.
By their numbers in this assay, from the lowest: compound 1; then compound 3; then compound 2.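

In this assay, with the carbamoyloxy chain held fixed, the change from ethyl to propyl gives a number 0.57 log units lower from compound 2 to compound 3 (beyond the scatter), so even one added methyl on this saturated chain carbon can move the number. With propyl held fixed on the other side of the shared core, carbamoyloxy in place of methyl gives a number 0.76 log units higher from compound 1 to compound 3 (beyond the scatter), which shows that the carbamoyloxy end on its own goes with a higher number. No measurement shown here explains either step.

Going by these compounds, whether a longer chain such as butyl would take the number lower still than propyl does remains open, as does the effect of a plain methyl in place of the ethyl. Also open, on these data alone, is whether a hydroxyl or an amine at the end of the chain would do what carbamoyloxy does.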